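Amino for hydrogen on a second benzylic chloride scaffold

A few compounds are considered here, and "the series" means these few. Any claim that something is new, unique, unknown or untested is made for them only; others in the source may bear on it.

Measured compounds:
compound 1 `ClCc1ccc(Cn2cnc3c(Cl)ncnc32)cc1`, 1310 nM
compound 2 `Nc1nc(Cl)c2ncn(Cc3ccc(CCl)cc3)c2n1`, 6610 nM
compound 3 `ClCc1ccccc1Cn1cnc2c(Cl)ncnc21`, 5620 nM

In a functional assay on DU-145 cells (Homo sapiens) for cytotoxicity, read by sulforhodamine B assay, with a stated time of 48 h (on this read-out higher numbers stand for weaker inhibition of growth and lower numbers for stronger inhibition of growth), compound 1 gives 1310 nM and compound 2 gives 6610 nM; the step of a 5.0-fold higher number from compound 1 to compound 2 (0.70 log units; beyond the scatter) follows the change (amino in place of hydrogen on an aromatic carbon). Compound 3 gives 5620 nM in this assay; the difference between its core and the core of compound 1 is not broken down here. Compound 4 `Nc1nc(Cl)c2ncn(Cc3ccccc3CCl)c2n1` is not yet measured; it differs from compound 3 by amino in place of hydrogen on an aromatic carbon, the same change as that from compound 1 to compound 2. From that earlier step, compound 4 is expected to give a weaker result than compound 3, with an estimated step of a 4.4-fold higher number from compound 3 to compound 4 (0.65 log units; beyond the scatter), resting on a 5.0-fold higher number from compound 1 to compound 2 (0.70 log units; beyond the scatter). Compound 4 is thus estimated at 25000 nM in this assay, within 9000 nM to 70000 nM.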

Compound 4, concentration for 50% growth inhibition: 14800 nM
Compound 4: middle estimate off by 1.7-fold (0.23 log units), on the high side, and the stated range covers the measured number.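

In this assay, amino in place of hydrogen on an aromatic carbon again gives weaker growth inhibition on the second core (a 2.6-fold higher number from compound 3 to compound 4 (0.42 log units; beyond the scatter)). The change therefore goes the same way on both cores, and the two steps cannot be told apart in size: the same change on two cores in this assay, a 5.0-fold higher number (0.70 log units; beyond the scatter) from compound 1 to compound 2 and a 2.6-fold higher number (0.42 log units; beyond the scatter) from compound 3 to compound 4, 1.9-fold (0.28 log units) apart, within the scatter of two such steps. This rests on just two pairs in one cell line, so it does not show that the step would hold on other cores, nor does it explain why the amino group has this effect.

The compounds shown leave open whether a methylamino or a hydroxyl group in place of the amino would give a similar step. They also leave open whether the step would persist if a benzylic bromide replaced the benzylic chloride.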